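Methoxy added to a hydroxamate indole: two matched pairs

The compounds below may be only part of what the source reports. "The series", "measured", "known", "first", "only" and "open" are said of these compounds alone.

Measured compounds:
compound 1, `COc1ccc(C(=O)c2ccc3c(ccn3Cc3ccc(C(=O)NO)cc3)c2)cc1OC`, 756 nM
compound 2, `COc1ccc(C(=O)c2ccc3c(ccn3Cc3ccc(C(=O)NO)cc3)c2)cc1`, 646 nM
compound 3, `COc1ccc(C(=O)c2ccc3c(ccn3S(=O)(=O)c3cccc(/C=C/C(=O)NO)c3)c2)cc1`, 812 nM

Of the compounds shown here, three have been tested in an assay on isolated protein for inhibition of histone deacetylase 8 (Homo sapiens); on this read-out lower numbers stand for stronger inhibition and higher numbers for weaker inhibition. Compound 2 gives 646 nM and compound 1 gives 756 nM. The two differ in one place, (methoxy in place of hydrogen on an aromatic carbon), and the step of a 1.2-fold higher number from compound 2 to compound 1 (0.07 log units; within the scatter). Compound 3 carries a different core; the difference between its core and that of compound 2 is not broken down here. In this assay compound 3 gives 812 nM, which sits close to the other two values.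

Compound 4, `COc1ccc(C(=O)c2ccc3c(ccn3S(=O)(=O)c3cccc(/C=C/C(=O)NO)c3)c2)cc1OC`, has not yet been measured. It differs from compound 3 by methoxy in place of hydrogen on an aromatic carbon, the same change that turns compound 2 into compound 1, and the surroundings of the place are the same in both pairs. Because a 1.2-fold higher number from compound 2 to compound 1 (0.07 log units; within the scatter), the corresponding step from compound 3 to compound 4 is expected to be small as well, a 1.2-fold higher number from compound 3 to compound 4 (0.07 log units; within the scatter), with the scatter of the assay allowing a modest shift either way. Compound 4 is therefore estimated at 950 nM in this assay, with a plausible range from 500 nM to 1800 nM.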

Compound 4, half-maximal inhibitory concentration: 1420 nM
For compound 4 the middle estimate is 1.5-fold (0.17 log units) below the measured one; measured number inside the range.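

In this assay, the change from (4-methoxyphenyl)carbonyl to (3,4-dimethoxyphenyl)carbonyl on the core of compound 3 gives a 1.7-fold higher number from compound 3 to compound 4 (0.24 log units; within the scatter), so on this core too the added methoxy leaves the number within the usual scatter of the measurement. Set side by side, the two matched pairs give no sign that the core alters what this change does, and the step seen on one core was a fair guide to the step on the other: the same change on two cores in this assay, a 1.2-fold higher number (0.07 log units; within the scatter) from compound 2 to compound 1 and a 1.7-fold higher number (0.24 log units; within the scatter) from compound 3 to compound 4, 1.5-fold (0.17 log units) apart, within the scatter of two such steps. Among these compounds, this agreement rests on only two pairs and on steps that are themselves small, so it does not show that the two steps are identical, that the added methoxy has any real effect on either core, or that the same would hold on a core beyond these two.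

The compounds shown leave open whether a different group in the same place, such as a hydroxyl, an amine or a longer ethoxy chain, would also carry from one core to the other with so little difference. They also leave open whether the agreement would survive if the hydroxamic acid on both cores gave way to a carboxylic acid.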